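The source may hold more compounds than are shown below. What is called first, only, known or untested is meant among the compounds shown, and "the series" means these compounds.

Two compounds here share one core and differ only in the tail of their ester. Compound 1 `CCOc1cc(NC(=O)C2(NC(=O)c3ccc4c(C5CCCC5)c(-c5ncc(Cl)cn5)n(C)c4c3)CCC2)ccc1/C=C/C(=O)OCC(C)C` carries an isopropyl group on that tail. In an ADME assay (liver) for pharmacokinetics, with Liver microsome (Rattus norvegicus) as the target, using microsomes (on this read-out lower numbers stand for a shorter-lived compound and higher numbers for a longer-lived compound), compound 1 gives 1.42 h. Compound 2 `CCOc1cc(NC(=O)C2(NC(=O)c3ccc4c(C5CCCC5)c(-c5ncc(Cl)cn5)n(C)c4c3)CCC2)ccc1/C=C/C(=O)OCCOCCOC` carries a (2-methoxyethoxy)methyl group in its place, and in this assay compound 2 gives 1.07 h. The step was a 1.3-fold lower number from compound 1 to compound 2 (0.12 log units; within the scatter). Compound 2 thus holds the lowest of the two numbers measured, but its nearest neighbour, compound 1, lies within the scatter, so no order between the two can be read.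

Compound 3 `CCOc1cc(NC(=O)C2(NC(=O)c3ccc4c(C5CCCC5)c(-c5ncc(Cl)cn5)n(C)c4c3)CCC2)ccc1/C=C/C(=O)OCC(=O)OC` is not yet measured. Against compound 2 it shows this change: methoxycarbonyl in place of (2-methoxyethoxy)methyl on a saturated chain carbon bound to an oxygen next to a carbonyl group. Going by the values given here, only one measured step touches the same place, the one from compound 1 to compound 2, and it stayed within the scatter. On that basis the step from compound 2 to compound 3 is expected to be a 1.1-fold lower number from compound 2 to compound 3 (0.03 log units; within the scatter), meaning no movement beyond the scatter. My estimate for compound 3 in this assay is 1 h, with a range from 0.5 h to 2 h.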

Compound 3, half-life: 2.08 h
Beside the measured number, compound 3's estimate is 2.1-fold (0.32 log units) below it; the whole stated range lies below it.
By their numbers in this assay, from the lowest: compounds 2, 1 and 3 (each within the scatter of the next).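

In this assay, methoxycarbonyl in place of (2-methoxyethoxy)methyl gives a 1.9-fold higher number from compound 2 to compound 3 (0.29 log units; within the scatter), and methoxycarbonyl in place of isopropyl gives a 1.5-fold higher number from compound 1 to compound 3 (0.17 log units; within the scatter). This place on the saturated chain carbon bound to an oxygen next to a carbonyl group now holds three different groups, one of them with a double bond outside aromatic rings and the other two without, and all three compounds remain within the usual scatter of one another, so the read-out gives no order among these groups. Nothing available here offers an explanation for how closely these half-lives agree.

What the three compounds leave open is whether this lack of separation would extend to quite different groups at the same place, such as an amine, a carboxylic acid, a cyclohexyl ring or a longer chain of carbon atoms. From the compounds shown here alone, all three also share the same core and the same ester link, so it remains open whether these tail groups would read the same way on another core or with an amide in place of that ester.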